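The source may hold more compounds than are shown below. What is called first, only, known or untested is meant among the compounds shown, and "the series" means these compounds.

In an ADME assay on L02 cells (Homo sapiens) for antiproliferative activity, read by MTT assay, with a stated time of 48 h (on this read-out higher numbers stand for weaker inhibition and lower numbers for stronger inhibition), two compounds built on one shared core have been measured. Compound 1 `CCc1ccccc1-n1nncc1CN1C(=O)C2(C(C#N)=C(N)Oc3c(N)cc4nc5ccccc5nc4c32)c2ccccc21` gives 22900 nM in this assay. Compound 2 `N#CC1=C(N)Oc2c(N)cc3nc4ccccc4nc3c2C12C(=O)N(Cc1cnnn1-c1c(F)cccc1F)c1ccccc12` gives > 50000 nM in this assay, which is a limit of the assay rather than a number (the limit of > 50000 nM in this assay, at which 1 of the 2 values shown sits). Going by the values given here, the only measured step at this position is an at least 2.1-fold higher number from compound 1 to compound 2 (0.33 log units; beyond the scatter), a change on the aromatic nitrogen of the five-membered aromatic ring with 3 nitrogen. Compound 3 `N#CC1=C(N)Oc2c(N)cc3nc4ccccc4nc3c2C12C(=O)N(Cc1cnnn1-c1ccc([N+](=O)[O-])cc1[N+](=O)[O-])c1ccccc12` is not yet measured and differs from compound 2 in one place: 2,4-dinitrophenyl in place of 2,6-difluorophenyl on an aromatic nitrogen. The measured step from compound 1 to compound 2 bears on this change, and it was modest, ending at the limit. Compound 2 already sits at that limit; a further weakening would again appear only as a limit. Compound 3 is therefore expected to stay at or beyond the limit, an estimated step that the limit leaves unreadable from compound 2 to compound 3. The estimate for compound 3 in this assay is 65000 nM, within a range from 25000 nM to 170000 nM.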

Compound 3, half-maximal inhibitory concentration: 22800 nM
Compound 3: middle estimate off by 2.9-fold (0.45 log units), on the high side, outside the stated range (below it).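

In this assay, stronger inhibition can return at this position: 2,4-dinitrophenyl in place of 2,6-difluorophenyl gives an at least 2.1-fold lower number from compound 2 to compound 3 (0.34 log units; beyond the scatter), so the weak end of the scale is not shared by every substituted phenyl here. Against 2-ethylphenyl, the same group gives a 1.0-fold lower number from compound 1 to compound 3 (0.00 log units; within the scatter), so two differently substituted phenyl groups read alike. The first of these steps has no upper end, because compound 2 stands at a limit of the assay and not at a number: the limit of > 50000 nM in this assay, at which 1 of the 3 values shown sits.

Going by these compounds alone, with only three phenyl groups, no single feature can be tied to the differences seen at this aromatic nitrogen. A phenyl ring bearing an amine or a carboxylic acid would show whether inhibition here can move beyond the level shared by compound 1 and compound 3.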